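Acylphloroglucinol dimers: cytotoxicity series

A few compounds are considered here, and "the series" means these few. Any claim that something is new, unique, unknown or untested is made for them only; others in the source may bear on it.

Measured compounds:
compound 1 `CC(=O)C1=C(O)C(C)(C)C(O)=C(CC2=C(O)C(C)(C)C(O)=C(C(C)=O)C2=O)C1=O` — > 50 ug/mL
compound 2 `CCC(=O)C1=C(O)C(C)(C)C(O)=C(Cc2c(O)c3c(c(C(C)=O)c2O)OC(C)(C)C=C3)C1=O` — 6.3 ug/mL
compound 3 `CCC(=O)C1=C(O)C(C)(C)C(O)=C(Cc2c(O)c3c(c(C(=O)CC)c2O)OC(C)(C)C=C3)C1=O` — 6.6 ug/mL

In a functional assay on cells (Cancer cell lines, Homo sapiens) for cytotoxicity, with a stated time of 72 h (a lower number here means that less compound is needed, a higher number that more compound is needed for the effect), compound 1 returns only a limit, > 50 ug/mL (the limit of > 50 ug/mL in this assay, at which 1 of the 3 values shown sits). Compound 2 gives 6.3 ug/mL, the lowest of the two numbers recorded. Compound 3 gives 6.6 ug/mL. The step of a 1.0-fold higher number from compound 2 to compound 3 (0.02 log units; within the scatter) shows that adding a methyl on a saturated chain carbon bound to a carbonyl carbon on the chromene half leaves the read-out unchanged within the scatter.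

The next compound, compound 4 `CC(=O)C1=C(O)C(C)(C)C(O)=C(Cc2c(O)c3c(c(C(C)=O)c2O)OC(C)(C)C=C3)C1=O`, awaits measurement in this assay. It differs from compound 2 by hydrogen in place of methyl on a saturated chain carbon bound to a carbonyl carbon. This is the mirror of the measured step: a methyl is removed rather than added, on the other acyl chain of the molecule.

Going by the values given here, only the step from compound 2 to compound 3 bears directly on this change, and it was within the scatter. The expected step of a 1.0-fold higher number from compound 2 to compound 4 (0.01 log units; within the scatter) is therefore none beyond the scatter, in no preferred direction. Compound 4 is estimated at 6.5 ug/mL, with a range from 3.2 ug/mL to 13 ug/mL. Compound 1 carries two acetyl groups and returned a limit, but it lacks the chromene ring of compound 4, so it does not test this step.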

Compound 4, concentration for half-maximal effect: 11 ug/mL
Estimate against measurement, compound 4: 1.7-fold (0.23 log units) below; the range from low to high includes it.
By their numbers in this assay, from the lowest: compounds 2, 3 and 4 (each within the scatter of the next). At a limit, above all of these: compound 1.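

In this assay, the change from propanoyl to acetyl on this acyl chain gives a 1.7-fold higher number from compound 2 to compound 4 (0.24 log units; within the scatter), so removing a methyl from a saturated chain carbon bound to a carbonyl carbon does not move the number beyond the scatter at this position. Earlier, only the other acyl chain had been read, through a 1.0-fold higher number from compound 2 to compound 3 (0.02 log units; within the scatter), and that step also lies within the scatter; the shared core now has one reading on each chain, and both readings agree in showing no change beyond the scatter, though a single pair per chain is a narrow basis. Nothing measured here bears on a cause for this step.

Any comparison of compound 3 with compound 4 cannot be read as a step, as these two compounds differ in two places. Still open is whether a longer chain such as butanoyl, or an amine or a carboxylic acid at the end of either acyl chain, would shift the number in this assay beyond the scatter, as the ethyl and methyl chains shown span only a small part of what this position could carry.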